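Swapping the Sulfonamide Amine: an Expected Binding Value

This account rests on a few compounds, and the source may have more. Where it says the series, first, only, none or still open, it means among the compounds named here.

Compound 1 `CCCn1c(=O)[nH]c2nc(-c3ccc(S(=O)(=O)N4CCN(c5ccc(Br)cc5)CC4)cc3)[nH]c2c1=O`: > 1000 nM, a limit.
Compound 2 `CCCn1c(=O)[nH]c2nc(-c3ccc(S(=O)(=O)N(C)C)cc3)[nH]c2c1=O`: 1220 nM.

Both compounds share one core and differ only in the amine attached to the sulfonyl group. Both were tested in an assay on CHO cells for displacement of a labelled ligand from adenosine receptor A3 (Homo sapiens), read by scintillation counting, with a stated time of 45 min, in the presence of a further agent that is not named here; on this read-out lower numbers stand for stronger inhibition and higher numbers for weaker inhibition. Among the measured compounds shown here, compound 2 gives 1220 nM in this assay, and that is the only actual number available. For compound 1 the assay reports only a limit, > 1000 nM, meaning (the limit of > 1000 nM in this assay, at which 1 of the 2 values shown sits). For the measured compounds named here, compound 2 therefore stands alone as the single measured value, and no comparison of strength between the two can be drawn.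

Compound 3 `CCCn1c(=O)[nH]c2nc(-c3ccc(S(=O)(=O)N4CCN(C)CC4)cc3)[nH]c2c1=O` has not yet been measured. Set against compound 2 it carries 4-methylpiperazin-1-yl in place of dimethylamino on a sulfonyl sulfur. Going by the values given here, no step between two measured compounds is available that would show how this kind of change behaves, so the expectation rests on the weak binding already seen for compound 2. I expect the step of a 1.2-fold higher number from compound 2 to compound 3 (0.09 log units; within the scatter) to remain within the usual scatter, in no clear direction. Compound 3 is therefore estimated at 1500 nM, with a range from 400 nM to 6000 nM.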

Compound 3, inhibition constant: > 1000 nM
Compound 3 ended at the assay's limit; the forecaster's own chance of this, stated with the estimate: 45%; the middle value is on the limit's open side.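

In this assay compound 3 gives > 1000 nM, a limit and not a number, so its steps from compound 2 and from compound 1 cannot be read. The same limit recurs: the limit of > 1000 nM in this assay, at which 2 of the 3 values shown sit. The compounds shown leave open whether the choice of amine on the sulfonyl sulfur changes binding at all.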